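The source may hold more compounds than are shown below. What is called first, only, known or untested is meant among the compounds shown, and "the series" means these compounds.

Among the measured compounds shown here, compound 2 `Cc1ccccc1-n1cc(CNC(=O)c2cccc3c2cnn3C(C)C)nn1` gives 19200 nM in a functional assay on PC-3 cells (Homo sapiens) for inhibition, read by MTT assay, with a stated time of 72 h (a higher number here means a weaker inhibitor, a lower number a stronger inhibitor), the only true number among the values shown. Compound 1 `CC(C)n1ncc2c(C(=O)NCc3cn(-c4ccc([N+](=O)[O-])cc4)nn3)cccc21` yields only a limit in this assay, > 40000 nM. For the measured compounds named here, the single measured step, an at least 2.0-fold lower number from compound 1 to compound 2 (0.31 log units; beyond the scatter), rests on (the limit of > 40000 nM in this assay, at which 1 of the 2 values shown sits). Compound 3 `COc1ccc(Cn2cc(CNC(=O)c3cccc4c3cnn4C(C)C)nn2)cc1` differs from compound 2 by 4-methoxybenzyl in place of 2-methylphenyl on an aromatic nitrogen. Going by the values given here, no measured step touches this kind of change, so the measured step offers no direct guide, and no shift beyond the scatter is anticipated. Compound 3 is therefore expected near 20000 nM, between 7000 nM and 45000 nM. This amounts to an expected step of a 1.0-fold higher number from compound 2 to compound 3 (0.02 log units; within the scatter).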

Compound 3, half-maximal inhibitory concentration: 34000 nM
The estimate for compound 3 lay 1.7-fold (0.23 log units) below the measured number; the range from low to high includes it.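

Replacing 2-methylphenyl with 4-methoxybenzyl on the aromatic nitrogen gives a 1.8-fold higher number from compound 2 to compound 3 (0.25 log units; within the scatter) in this assay, so this change, which adds a hydrogen-bond acceptor, does not separate the two compounds. The step of an at least 1.1-fold lower number from compound 1 to compound 3 (0.07 log units; that floor lies within the scatter) likewise gives no order. Compound 1 remains hard to place because its value is only a limit: the limit of > 40000 nM in this assay, at which 1 of the 3 values shown sits.

Because this change alters the group in more than one way, the compounds leave open what an unsubstituted benzyl group on this nitrogen would give. They also leave open whether a carboxylic acid or an amine on the aromatic ring would move the number beyond the scatter.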